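This account rests on a few compounds, and the source may have more. Where it says the series, first, only, none or still open, it means among the compounds named here.

Measured so far:
compound 1 `CC(C)OC(=O)N1CCC(Oc2cccc3c2CCN3c2ccc(S(C)(=O)=O)cc2F)CC1`, 1000 nM
compound 2 `CC(C)OC(=O)N1CCC(Oc2ncnc3c2CCN3c2ccc(-c3cccn3C)cc2F)CC1`, 158 nM
compound 3 `CCOC(=O)N1CCC(Oc2ncnc3c2CCN3c2ccc(S(C)(=O)=O)cc2F)CC1`, 251 nM

All three were tested in a functional assay on CHO-K1 cells for agonist activity at Glucose-dependent insulinotropic receptor (Homo sapiens), read by a luciferase reporter, with a stated time of 5 h; on this read-out lower numbers stand for an effect already at smaller amounts and higher numbers for an effect only at larger amounts of compound. Among these three numbers compound 3 stands second highest. Its nearest neighbour is compound 2, whose number lies within the usual scatter of compound 3, so the two cannot be told apart on this evidence. Its furthest neighbour is compound 1, whose number lies beyond the scatter and is higher than that of compound 3.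

Compound 4 `CCS(=O)(=O)N1CCC(Oc2ncnc3c2CCN3c2ccc(S(C)(=O)=O)cc2F)CC1` has not yet been measured. It differs from compound 3 in one place: ethylsulfonyl in place of ethoxycarbonyl on an amine nitrogen in a ring. Going by the values given here, no measured pair shows what this kind of exchange does here, so no step of known size can be drawn on. Both groups carry the same count of hydrogen-bond acceptors and no donors, and the shared core is unchanged. The step of a 1.6-fold higher number from compound 3 to compound 4 (0.20 log units; within the scatter) is expected to be small, possibly a slight rise, not clearly beyond the scatter. Compound 4 is therefore estimated at 400 nM, within a range from 150 nM to 1200 nM.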

Compound 4, half-maximal effective concentration: 1580 nM
Beside the measured number, compound 4's estimate is 4.0-fold (0.60 log units) below it; measured number outside the range, above it.
By their numbers in this assay, from the lowest: compounds 2 and 3 (each within the scatter of the next); then compounds 1 and 4 (each within the scatter of the next).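

In this assay, going by these compounds alone, the exchange on this amine nitrogen in a ring gives the first step that can be read in one place: a 6.3-fold higher number from compound 3 to compound 4 (0.80 log units; beyond the scatter). The position therefore responds to the choice of group, even though ethoxycarbonyl and ethylsulfonyl have matching counts of heavy atoms, hydrogen-bond donors and hydrogen-bond acceptors, so those counts alone do not settle the outcome here. Nothing available gives a reason for this step.

As far as these compounds go, this is a single pair, so whether the same exchange would have a similar effect with the other parts of compound 2 remains open. From the compounds shown here alone, it is also open how an acetyl group, a urea or a longer chain on this nitrogen would compare with ethoxycarbonyl.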